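Aryl swap on the core of compound 2

The compounds below may be only part of what the source reports. "The series", "measured", "known", "first", "only" and "open" are said of these compounds alone.

Compound 2 `O=Cc1ccc(-c2cn3ccnc3c(-c3ccc4ncn(C5CCCCC5)c4c3)n2)cc1` stands highest of the two numbers in a functional assay on CCRF-CEM cells (Homo sapiens) for inhibition, read by sulforhodamine B assay, with a stated time of 48 h, tested at 10 uM; on this read-out lower numbers stand for less inhibition and higher numbers for more inhibition at the one concentration tested (going by the name of the read-out): compound 2 gives 77.9%, while compound 1 `Brc1cn2ccnc2c(-c2ccc3ncn(C4CCCCC4)c3c2)n1` gives 7.68%. The step of a number 70.2 percentage points higher from compound 1 to compound 2 (beyond the scatter) is the only measured one and shows the size of the gain when an aryl group enters there. Compound 3 `COc1ccccc1-c1cn2ccnc2c(-c2ccc3ncn(C4CCCCC4)c3c2)n1` differs from compound 2 by 2-methoxyphenyl in place of 4-formylphenyl on an aromatic carbon. Among the measured compounds shown here, no measured step covers an aryl-for-aryl swap, so the expected step is far smaller, a modest fall or none beyond the scatter, estimated as a number 15.9 percentage points lower from compound 2 to compound 3 (beyond the scatter). Compound 3 is expected to give about 62%, within 30% to 85%.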

Compound 3, a percentage reported as inhibition, at one concentration (the size of the read-out at that concentration, not a potency): 17.4%
Compound 3: the middle estimate sits 44.6 percentage points above what was measured; measured number below the stated range.
By their numbers in this assay, from the lowest: compounds 1 and 3 (each within the scatter of the next); then compound 2.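

In this assay, an aryl group at this aromatic carbon does not by itself carry the result: the two aryl groups here have the same heavy-atom count, yet the step is a number 60.5 percentage points lower from compound 2 to compound 3 (beyond the scatter). The step of a number 9.7 percentage points higher from compound 1 to compound 3 (within the scatter) leaves 2-methoxyphenyl level with bromo, so the gain seen so far belongs to 4-formylphenyl alone among these groups. No measurement offered here bears on the reason.

The compounds shown leave open whether the formyl group or its place on the phenyl ring matters, since the two aryl groups differ in both. Unsubstituted phenyl, 4-methoxyphenyl and 2-formylphenyl would separate these two readings.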